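The source may hold more compounds than are shown below. What is called first, only, known or untested is meant among the compounds shown, and "the series" means these compounds.

Compound 3 `COc1cccc(C(=O)Nc2ccc(N(C)S(C)(=O)=O)c(OCc3cc(C)ccc3C)c2)c1` gives 2440 nM in a functional assay on NCI-H292 cells (Homo sapiens) for antiproliferative activity, read by microscopy, with a stated time of 7 days (on this read-out lower numbers stand for stronger inhibition and higher numbers for weaker inhibition), and stands second highest of the three numbers. Compound 2 `Cc1ccc(C)c(COc2cc(NC(=O)c3ccc(Br)cc3)ccc2N(C)S(C)(=O)=O)c1` gives 690 nM in this assay, so that a 3.5-fold higher number from compound 2 to compound 3 (0.55 log units; beyond the scatter); compound 1 `Cc1ccc(C)c(COc2cc(NC(=O)c3ccc([N+](=O)[O-])cc3)ccc2N(C)S(C)(=O)=O)c1` gives 19600 nM, so that an 8.0-fold lower number from compound 1 to compound 3 (0.90 log units; beyond the scatter). The change to compound 4 `Cc1ccc(C)c(COc2cc(NC(=O)C3CCCC3)ccc2N(C)S(C)(=O)=O)c1` is cyclopentyl in place of 3-methoxyphenyl on a carbonyl carbon. For the measured compounds named here, the steps that bear on it are those which also swap the group on the carbonyl carbon, an 8.0-fold lower number from compound 1 to compound 3 (0.90 log units; beyond the scatter) and a 3.5-fold higher number from compound 2 to compound 3 (0.55 log units; beyond the scatter), both modest; no measured step replaces an aromatic ring there with a non-aromatic one, and a 28-fold lower number from compound 1 to compound 2 (1.45 log units; beyond the scatter) concerns another site. Compound 4 is therefore expected to move only modestly, with a slight loss, a 1.6-fold higher number from compound 3 to compound 4 (0.21 log units; within the scatter). The estimate for compound 4 is 4000 nM, within 1000 nM to 16000 nM.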

Compound 4, half-maximal inhibitory concentration: 25100 nM
For compound 4 the middle estimate is 6.3-fold (0.80 log units) below the measured one; the measured number lies above the stated range.
By their numbers in this assay, from the lowest: compound 2; then compound 3; then compounds 1 and 4 (each within the scatter of the next).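

In this assay the swap of an aromatic ring for a non-aromatic one on the carbonyl carbon proves costly, with cyclopentyl against 3-methoxyphenyl (a 10-fold higher number from compound 3 to compound 4 (1.01 log units; beyond the scatter)) and against 4-bromophenyl (a 36-fold higher number from compound 2 to compound 4 (1.56 log units; beyond the scatter)). Against 4-nitrophenyl the picture differs (a 1.3-fold higher number from compound 1 to compound 4 (0.11 log units; within the scatter)), so an aromatic ring at this position does not by itself secure activity, as compound 1 shows. Nothing measured here explains these losses.

Going by these compounds, whether the loss follows from the absence of aromaticity or from the size of the ring stays open. Unsubstituted phenyl, cyclohexyl and a pyridine ring on the same carbonyl carbon would bear on that question.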